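A few compounds are considered here, and "the series" means these few. Any claim that something is new, unique, unknown or untested is made for them only; others in the source may bear on it.

Compound 1 `CCOc1nc2cccc(C(=O)NCCCN(C)C)c2n1Cc1ccc(-c2ccccc2-c2nnn[nH]2)cc1` gives 29.5% in an assay on isolated protein for inhibition of NEDD8-activating enzyme E1 regulatory subunit (Homo sapiens), read by Western blot, with stated times of 10 min and 30 min, tested at 25 uM; a higher number here means more inhibition at the concentration tested (going by the name of the read-out), a lower number less inhibition. Compound 2 `CCOc1nc2cccc(C(=O)NCCCOC)c2n1Cc1ccc(-c2ccccc2-c2nnn[nH]2)cc1` gives 27.9% in this assay.

On these two numbers compound 2 stands level with compound 1, the gap between them within the scatter. Compound 3 `CCOC(=O)CNC(=O)c1cccc2nc(OCC)n(Cc3ccc(-c4ccccc4-c4nnn[nH]4)cc3)c12` differs from compound 2 by ethoxycarbonyl in place of 2-methoxyethyl on a saturated chain carbon bound to an amide-type nitrogen. Within the data shown here, the only measured step, a number 1.6 percentage points lower from compound 1 to compound 2 (within the scatter), alters another part of the chain and stays within the scatter, so it bears only loosely on this change, and no step of the same kind has been measured. The expected step is therefore a number 0.9 percentage points lower from compound 2 to compound 3 (within the scatter), nothing beyond the scatter. Compound 3 is estimated at 27%, between 10% and 45%, in this assay.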

Compound 3, a percentage reported as inhibition, at one concentration (the size of the read-out at that concentration, not a potency): 46.5%
The estimate for compound 3 lay 19.5 percentage points below the measured number; measured number above the stated range.
By their numbers in this assay, from the lowest: compounds 2 and 1 (each within the scatter of the next); then compound 3.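

Ethoxycarbonyl in place of 2-methoxyethyl on a saturated chain carbon bound to an amide-type nitrogen gives a number 18.6 percentage points higher from compound 2 to compound 3 (beyond the scatter) in this assay and, in place of 2-(dimethylamino)ethyl at the same carbon, gives a number 17 percentage points higher from compound 1 to compound 3 (beyond the scatter) in the same test. Among these compounds, the earlier pair showed no difference beyond the scatter, so compound 3 is the first here to show that this side chain can shift the read-out. Nothing measured here explains the rise. Going by these compounds, whether it survives with a carboxylic acid in place of the ethyl ester, or with a longer chain carrying the same ester, remains open.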